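This account rests on a few compounds, and the source may have more. Where it says the series, first, only, none or still open, it means among the compounds named here.

Going by the values given here, compound 1, with the structure `COC(=O)c1ccc(-c2cnc(C(=O)CCCCCCc3ccccc3)o2)cc1`, is the first of the compounds considered. In an assay (Rattus norvegicus) for inhibition of Fatty-acid amide hydrolase 1 (Homo sapiens) (on this read-out higher numbers stand for weaker inhibition and lower numbers for stronger inhibition), compound 1 gives 40 nM. Compound 2, with the structure `O=C(O)c1ccc(-c2cnc(C(=O)CCCCCCc3ccccc3)o2)cc1`, carries the change hydrogen in place of methyl on an oxygen next to a carbonyl group relative to compound 1, and in this assay compound 2 gives 60 nM. The step of a 1.5-fold higher number from compound 1 to compound 2 (0.18 log units; within the scatter) shows that this change, on this core, left the inhibition essentially where it was.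

Compound 3 has the structure `COC(=O)c1cccc(-c2cnc(C(O)CCCCCCc3ccccc3)o2)n1`. How its core differs from the core of compound 1 is not broken down here. In this assay compound 3 gives 2300 nM, the highest number among the three measured compounds and beyond the scatter from both compound 1 and compound 2.

Compound 4, with the structure `O=C(O)c1cccc(-c2cnc(C(O)CCCCCCc3ccccc3)o2)n1`, is not yet measured. Relative to compound 3 it carries the change (hydrogen in place of methyl on an oxygen next to a carbonyl group), which is the same change that separates compound 1 from compound 2, at the same place in the molecule. Because the step of a 1.5-fold higher number from compound 1 to compound 2 (0.18 log units; within the scatter) stayed within the scatter, the expectation is that the same change on the core of compound 3 behaves alike, so a step of about a 1.3-fold higher number from compound 3 to compound 4 (0.12 log units; within the scatter) is expected from compound 3 to compound 4, with the caution that the change has been seen only once and on a different core. Compound 4 is therefore estimated at 3000 nM in this assay, in a range from 1200 nM to 8000 nM.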

Compound 4, inhibition constant: > 10000 nM
Compound 4 was reported as a limit (the forecaster's own chance of this, stated with the estimate: 10%); middle value at least 3.3-fold (0.52 log units) away from the limit.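

In this assay, the change from methoxycarbonyl to carboxy did not carry over at the same size from one core to the other, the new step being an at least 4.3-fold higher number from compound 3 to compound 4 (0.63 log units; beyond the scatter), which sets it apart from the earlier step: the same change on two cores in this assay, a 1.5-fold higher number (0.18 log units; within the scatter) from compound 1 to compound 2 and an at least 4.3-fold higher number (0.63 log units; beyond the scatter) from compound 3 to compound 4, at least 2.8-fold (0.46 log units) apart, beyond the scatter of two such steps. On these data alone, compound 4 gives > 10000 nM, which is a limit of the assay and not a number, so only the minimum size of the new step can be read and its full size stays unknown: the limit of > 10000 nM in this assay, at which 1 of the 4 values shown sits. The comparison shows that, for these two pairs, the effect of the change depends on the core it sits on, but it rests on a single pair per core and does not show which feature of the two cores is responsible, nor does it give a rule for any other core.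

The compounds shown leave open how an amide or a nitrile in place of the methoxycarbonyl would read on either core, and whether a shorter chain would alter the size of the step. Also open, as far as these compounds go, is how the same change would behave on a third core, and where compound 4 would fall if a number could be read for it.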